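Trifluoromethyl for chloro, with stability readings at a limit

The source may report more compounds than this note shows. Statements on the series, on what has been measured and on what is new or still open speak of the compounds shown alone.

In an ADME assay on microsomes from liver (Rattus norvegicus) for metabolic stability (a lower number here means that the compound disappears faster, a higher number that the compound lasts longer), compound 1 `N#Cc1ccc(-c2nc(NCCNc3ccc([N+](=O)[O-])c(N)n3)ncc2-c2ncc[nH]2)cc1` gives > 0.5 h, which is a limit and not a number. Compound 2 `Nc1nc(NCCNc2ncc(-c3ncc[nH]3)c(-c3ccc(F)cc3F)n2)ccc1[N+](=O)[O-]` gives > 0.5 h, also a limit. Compound 3 `Nc1nc(NCCNc2ncc(-c3ncc[nH]3)c(-c3ccc(F)cc3Cl)n2)ccc1[N+](=O)[O-]` gives > 0.5 h, again a limit. All three therefore stand at the limit of > 0.5 h in this assay, at which 3 of the 3 values shown sit.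

Compound 4 `Nc1nc(NCCNc2ncc(-c3ncc[nH]3)c(-c3ccc(F)cc3C(F)(F)F)n2)ccc1[N+](=O)[O-]` carries trifluoromethyl in place of chloro on an aromatic carbon. The closest measured change, chloro in place of fluoro, is a step that the two limits leave unreadable from compound 2 to compound 3. Replacing 4-cyanophenyl gives a step that the two limits leave unreadable from compound 1 to compound 2 and a step that the two limits leave unreadable from compound 1 to compound 3. None of these offers a size or direction to carry over.

The expected result is a step that the limit leaves unreadable from compound 3 to compound 4, with no change expected beyond the usual scatter. Compound 4 is estimated at 0.8 h, with an expected range of 0.45 h to 2 h.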

Compound 4, half-life: > 0.5 h
Compound 4: no number, only a limit; the forecaster's own chance of this, stated with the estimate: 80%; the middle value does not contradict the limit.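

No step to compound 4 from compound 1, compound 2 or compound 3 can be read in this assay, because each result is a limit and not a number: the limit of > 0.5 h in this assay, at which 4 of the 4 values shown sit.

As far as these compounds go, how long these four compounds actually last, and whether trifluoromethyl in place of chloro changes that at all, remains open.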